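A few compounds are considered here, and "the series" means these few. Any claim that something is new, unique, unknown or untested is made for them only; others in the source may bear on it.

Measured compounds:
Compound 1 `CC1=C(C(=O)OCc2ccccc2)C(c2ccsc2)NC(=O)N1`: 25%
Compound 2 `CC1=C(C(=O)OC2CCCC2)C(c2ccoc2)NC(=O)N1`: 1%

In an assay on membranes from HeLa cells for displacement of a labelled ligand from adenosine receptor A3 (Homo sapiens), read by scintillation counting, with a stated time of 180 min, tested at 1 uM (a higher number here means more inhibition at the concentration tested (going by the name of the read-out), a lower number less inhibition), compound 2 stands lowest of the two, with compound 1 the nearer one and beyond the scatter above it. Compound 3 `CC1=C(C(=O)OC2CCCC2)C(c2ccsc2)NC(=O)N1` is not yet measured. It differs from compound 2 in one place: thiophen-3-yl in place of furan-3-yl on a saturated ring carbon. Among the compounds with values here, no single-change step between measured compounds exists, and compound 1 differs from compound 2 in more than one place. A rise is expected for compound 3, estimated at 12% (range 0% to 32%), partly because compound 1 gives 25%. This expected step a number 11 percentage points higher from compound 2 to compound 3 (beyond the scatter) may well remain within the scatter.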

Compound 3, a percentage reported as inhibition, at one concentration (the size of the read-out at that concentration, not a potency): 5%
Beside the measured number, compound 3's estimate is 7 percentage points above it; measured number inside the range.
By their numbers in this assay, from the lowest: compounds 2 and 3 (each within the scatter of the next); then compound 1.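

In this assay the change from furan-3-yl to thiophen-3-yl on the saturated ring carbon gives a number 4 percentage points higher from compound 2 to compound 3 (within the scatter) and so, with cyclopentyl on the ester oxygen, does not separate the two rings. The group on that oxygen does matter with thiophen-3-yl in place: cyclopentyl in place of benzyl gives a number 20 percentage points lower from compound 1 to compound 3 (beyond the scatter) and accounts for the gap to the benzyl compound. Nothing measured here explains either step.

On these data alone, whether the two rings would also match with benzyl on the oxygen remains open. So does whether a pyridin-3-yl or a phenyl ring at this carbon would give a different reading.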